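Methyl to chloro exchange on the aryl ring, two cores

The source may hold more compounds than are shown below. What is called first, only, known or untested is meant among the compounds shown, and "the series" means these compounds.

Measured so far in a functional assay on HeLa cells (Homo sapiens) for cytotoxicity, read by MTT assay, with a stated time of 48 h; on this read-out higher numbers stand for weaker inhibition and lower numbers for stronger inhibition:
compound 1, `CCOC(=O)c1c(-c2c(Cl)c3ccccc3oc2=O)nn(-c2cccc(C)c2)c1C(=O)OCC`: 30000 nM
compound 2, `CCOC(=O)c1c(-c2c(Cl)c3ccccc3oc2=O)nn(-c2cccc(Cl)c2)c1C(=O)OCC`: 40000 nM
compound 3, `CCOC(=O)c1c(-c2cc3cc(OC)ccc3oc2=O)nn(-c2cccc(C)c2)c1C(=O)OCC`: 155000 nM

Compound 2 differs from compound 1 by chloro in place of methyl on an aromatic carbon, and the step is a 1.3-fold higher number from compound 1 to compound 2 (0.12 log units; within the scatter). Compound 3 carries a different core; the difference between the two cores is not broken down here. Compound 3 gives the highest number of the three in this assay, beyond the scatter from both compound 1 and compound 2.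

Compound 4, `CCOC(=O)c1c(-c2cc3cc(OC)ccc3oc2=O)nn(-c2cccc(Cl)c2)c1C(=O)OCC`, is not yet measured. It differs from compound 3 by chloro in place of methyl on an aromatic carbon, the same change made from compound 1 to compound 2, with the same surroundings at the place of change. Because that step was a 1.3-fold higher number from compound 1 to compound 2 (0.12 log units; within the scatter), compound 4 is expected to sit close to compound 3, with an estimated step of a 1.2-fold higher number from compound 3 to compound 4 (0.06 log units; within the scatter) in this assay. The estimate for compound 4 is 180000 nM, expected between 90000 nM and 360000 nM.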

Compound 4, half-maximal inhibitory concentration: 160000 nM
Beside the measured number, compound 4's estimate is 1.1-fold (0.05 log units) above it; the measured number falls inside the stated range.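

In this assay, going from 3-methylphenyl to 3-chlorophenyl on the methoxy-bearing core gives a 1.0-fold higher number from compound 3 to compound 4 (0.01 log units; within the scatter). The exchange reads the same on both cores: the same change on two cores in this assay, a 1.3-fold higher number (0.12 log units; within the scatter) from compound 1 to compound 2 and a 1.0-fold higher number (0.01 log units; within the scatter) from compound 3 to compound 4, 1.3-fold (0.11 log units) apart, within the scatter of two such steps. This is agreement between two steps that are each within the scatter, on two cores only; it does not show that the exchange would stay this small on any other core, and it does not break down the difference between the two cores.

Open, from the compounds shown here alone, is what an amine or a carboxylic acid in place of the methyl or chloro would do on either core. Also open is whether the ethyl esters, shared by all the compounds shown, could give way to a carboxylic acid or an amide.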